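The compounds below may be only part of what the source reports. "The series", "measured", "known", "first", "only" and "open" are said of these compounds alone.

Among the compounds with values here, compound 2 `CCn1c(C(=O)NCCCN(C)C)ccc1C(CC)(CC)c1ccc(OCC(O)C(C)(C)C)c(C)c1` gives 37 nM in an assay on HL-60 cells for agonist activity at vitamin D3 receptor (Homo sapiens), read by microscopy, with a stated time of 96 h (a lower number here means that less compound is needed, a higher number that more compound is needed for the effect), the lower of the two numbers measured so far; compound 1 `CCn1c(C(=O)NCCCN(C)C)ccc1C(CC)(CC)c1ccc(OCC(=O)C(C)(C)C)c(C)c1` gives 96 nM, and the step of a 2.6-fold lower number from compound 1 to compound 2 (0.41 log units; beyond the scatter) lies beyond the scatter. Compound 3 `CC[C@@H](C)[C@H](NC(=O)c1ccc(C(CC)(CC)c2ccc(OCC(O)C(C)(C)C)c(C)c2)n1CC)C(=O)O` differs from compound 2 by 1-carboxy-2-methylbutyl in place of 3-(dimethylamino)propyl on an amide-type nitrogen. Within the data shown here, no measured step touches the amide-type nitrogen, and the step of a 2.6-fold lower number from compound 1 to compound 2 (0.41 log units; beyond the scatter) changed a different part of the molecule, so there is no close guide. Compound 3 is therefore expected near compound 2, with a wide range: an estimate of 45 nM, between 10 nM and 200 nM, a step of a 1.2-fold higher number from compound 2 to compound 3 (0.09 log units; within the scatter).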

Compound 3, half-maximal effective concentration: 2.3 nM
The estimate for compound 3 lay 20-fold (1.29 log units) above the measured number; the measured number lies below the stated range.
By their numbers in this assay, from the lowest: compound 3; then compound 2; then compound 1.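

Within the data shown here, the amide-type nitrogen proves to be a sensitive position in this assay: 1-carboxy-2-methylbutyl in place of 3-(dimethylamino)propyl gives a 16-fold lower number from compound 2 to compound 3 (1.21 log units; beyond the scatter) and thereby the lowest number so far. The earlier step, a 2.6-fold lower number from compound 1 to compound 2 (0.41 log units; beyond the scatter), changed a different part of the molecule and said nothing about this nitrogen. No measurement at hand gives a reason for the new step.

The compounds shown leave open whether the carboxy group, the carbon chain or the two defined stereocentres carries this step. A methyl ester in place of the carboxylic acid, or a simple glycine chain, would help separate these parts.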